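Sulfonyl-ethenyl amide series: fluoro to methoxy swap

The source may hold more compounds than are shown below. What is called first, only, known or untested is meant among the compounds shown, and "the series" means these compounds.

Working notes on three measured analogues and one pending. In a functional assay on A549 cells (Homo sapiens) for cytotoxicity, read by MTT assay, with a stated time of 72 h (a lower number here means a stronger inhibitor, a higher number a weaker inhibitor), compound 1 `COc1cc2c(Oc3ccc(NC(=O)c4cn(-c5ccc(Cl)cc5)cn4)cc3F)ccnc2cc1OCCCN1CCN(C)CC1` gives 5200 nM. Compound 2 `COc1cc2c(Oc3ccc(NC(=O)c4cn(-c5cc(C)ccc5C)cn4)cc3F)ccnc2cc1OCCCN1CCCCC1` gives 510 nM. Compound 3 `COc1cc2c(Oc3ccc(NC(=O)/C=C/S(=O)(=O)c4ccccc4F)cc3F)ccnc2cc1OCCCN1CCN(C)CC1` gives 150 nM, the lowest of the three numbers, with compound 2 nearest and compound 1 furthest. For the measured compounds named here, the only single-point step measured, a 35-fold lower number from compound 1 to compound 3 (1.54 log units; beyond the scatter), exchanged the entire group on the amide carbonyl. Compound 4 `COc1cc2c(Oc3ccc(NC(=O)/C=C/S(=O)(=O)c4ccccc4OC)cc3F)ccnc2cc1OCCCN1CCN(C)CC1` differs from compound 3 by methoxy in place of fluoro on an aromatic carbon. Going by the values given here, no measured step touches the substituent on the phenyl of the (2-fluorophenyl)sulfonyl group, so that large step offers no direct guide and nothing argues for a shift beyond the scatter. The expected step is a 1.1-fold higher number from compound 3 to compound 4 (0.03 log units; within the scatter). Compound 4 is estimated at 160 nM, range 50 nM to 500 nM.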

Compound 4, half-maximal inhibitory concentration: 320 nM
The estimate for compound 4 lay 2.0-fold (0.30 log units) below the measured number; the range from low to high includes it.
By their numbers in this assay, from the lowest: compound 3; then compounds 4 and 2 (each within the scatter of the next); then compound 1.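

Methoxy in place of fluoro gives a 2.1-fold higher number from compound 3 to compound 4 (0.33 log units; beyond the scatter) in this assay, the first measured step at this aromatic carbon, where the earlier compounds showed only an exchange of the entire group on the amide carbonyl. The step is modest, but it shows that the substituent on this phenyl can move the number, with fluoro giving the lower value in this single pair. No measurement here explains the difference. Open, from the compounds shown here alone, is how hydrogen, chloro or trifluoromethyl would read at this carbon, and whether the step would hold with piperidine in place of the methylpiperazine.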